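Compound 3: a trifluoromethyl swap on the aryl amine

The source may hold more compounds than are shown below. What is called first, only, known or untested is meant among the compounds shown, and "the series" means these compounds.

Values in a physicochemical assay for lipophilicity (a lower number here means a more polar compound, a higher number a more lipophilic compound), so far
compound 1 `C=C(c1cccc2ccccc12)C1CCC2(CC1)COC(Nc1ccccc1)OO2` gives 5.59
compound 2 `C=C(c1cccc2ccccc12)C1CCC2(CC1)COC(Nc1ccc(C)cc1)OO2` gives 6.08

In this assay compound 2 stands at 6.08 and holds the higher of the two numbers. Compound 3 `C=C(c1cccc2ccccc12)C1CCC2(CC1)COC(Nc1cccc(C(F)(F)F)c1)OO2` is not yet measured and differs by 3-(trifluoromethyl)phenyl in place of 4-methylphenyl on an amine nitrogen in that 3-(trifluoromethyl)phenyl stands in place of 4-methylphenyl on an amine nitrogen. Among the compounds with values here, the one measured step bearing on this is a number 0.49 log units higher from compound 1 to compound 2 (beyond the scatter) for methyl in place of hydrogen on an aromatic carbon, a modest change beyond the scatter. A further modest rise of similar or slightly smaller size is expected, estimated as a number 0.37 log units higher from compound 2 to compound 3 (beyond the scatter) in the upward direction. Compound 3 is estimated at 6.45 with an expected range from 6.05 to 6.85 in this assay when it is measured.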

Compound 3, partition coefficient: 6.51
Estimate against measurement, compound 3: 0.06 log units below; the measured number falls inside the stated range.
By their numbers in this assay, from the lowest: compound 1; then compound 2; then compound 3.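

In this assay, the aryl group on the amine nitrogen again tolerates a change that moves the number upward: 3-(trifluoromethyl)phenyl in place of 4-methylphenyl gives a number 0.43 log units higher from compound 2 to compound 3 (beyond the scatter), and trifluoromethyl in place of hydrogen on an aromatic carbon gives a number 0.92 log units higher from compound 1 to compound 3 (beyond the scatter). Two different substituted aryl groups now lie beyond the scatter above the plain phenyl of compound 1, and the larger step belongs to trifluoromethyl. Nothing available explains these rises.

As far as these compounds go, whether 4-(trifluoromethyl)phenyl would read like 3-(trifluoromethyl)phenyl stays open. So does where a carboxylic acid or an amine on this ring would fall.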